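Adding a Second Chlorine to the Benzylic Ring of Compound 1

The source may report more compounds than this note shows. Statements on the series, on what has been measured and on what is new or still open speak of the compounds shown alone.

Among the compounds with values here, compound 1 `CC(C)Cc1ccc(C(C)C(=O)NCc2ccccc2)cc1` is measured in an assay on brain for inhibition of Fatty-acid amide hydrolase 1 (Rattus norvegicus), read by scintillation counting, with a stated time of 10 min (a lower number here means a stronger inhibitor, a higher number a weaker inhibitor), where compound 1 gives 21000 nM, the second highest of the three numbers so far. Compound 2 `CC(C)Cc1ccc(C(C)C(=O)NCc2ccc(Cl)cc2)cc1` gives 27000 nM, and compound 3 `CC(C)Cc1ccc(C(C)C(=O)NCc2ccccc2Cl)cc1` gives 4100 nM. Compound 4 `CC(C)Cc1ccc(C(C)C(=O)NCc2ccc(Cl)c(Cl)c2)cc1` is not yet measured; it carries 3,4-dichlorophenyl in place of phenyl on a saturated chain carbon bound to an amide-type nitrogen. Within the data shown here, two measured steps bear on this, each adding one chlorine to that ring: a 1.3-fold higher number from compound 1 to compound 2 (0.11 log units; within the scatter) and a 5.1-fold lower number from compound 1 to compound 3 (0.71 log units; beyond the scatter). Between those two, a 6.6-fold lower number from compound 2 to compound 3 (0.82 log units; beyond the scatter). Among the measured compounds shown here, compound 4 keeps the chlorine of compound 2, whose step stayed within the scatter, and its second chlorine is not the one compound 3 carries, so only a small step is expected. The estimate for compound 4 is 14000 nM, ranging from 5000 nM to 40000 nM, an expected 1.5-fold lower number from compound 1 to compound 4 (0.18 log units; within the scatter).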

Compound 4, half-maximal inhibitory concentration: 36000 nM
The estimate for compound 4 lay 2.6-fold (0.41 log units) below the measured number, and the stated range covers the measured number.
By their numbers in this assay, from the lowest: compound 3; then compounds 1, 2 and 4 (each within the scatter of the next).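

In this assay, the ring with two chlorines stays within the scatter of the plain phenyl ring, a 1.7-fold higher number from compound 1 to compound 4 (0.23 log units; within the scatter), and the second chlorine shifts nothing beyond it, a 1.3-fold higher number from compound 2 to compound 4 (0.12 log units; within the scatter). The 2-chlorophenyl group alone stands apart, an 8.8-fold higher number from compound 3 to compound 4 (0.94 log units; beyond the scatter), which means that among these compounds, where a chlorine sits counts for more than how many are present. Adding one chlorine has no single effect at this position: the same change on two cores in this assay, a 5.1-fold lower number (0.71 log units; beyond the scatter) from compound 1 to compound 3 and a 1.3-fold higher number (0.12 log units; within the scatter) from compound 2 to compound 4, 6.8-fold (0.83 log units) apart, beyond the scatter of two such steps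

Still open, from the compounds shown here alone, is whether a bromine or a methoxy group in place of the chlorine of compound 3 would keep its lower number.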